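The compounds below may be only part of what the source reports. "The series", "measured", "known", "first", "only" and "open" are said of these compounds alone.

Compound 1 `O=S(=O)(Nc1cccc(CO)c1)c1ccc(-c2ccc(Br)cc2)cc1` gives 2500 nM in a functional assay on J774 cells (Mus musculus) for cytotoxicity, read by resazurin assay, with a stated time of 72 h; a higher number here means a weaker inhibitor, a lower number a stronger inhibitor.
Compound 2 `O=S(=O)(Nc1cccc(CO)c1)c1ccc(-c2ccc(Br)cc2F)cc1` gives 1000 nM in this assay.
Compound 3 `O=S(=O)(Nc1cccc(CO)c1)c1ccc(-c2ccc(Cl)cc2)cc1` gives 2500 nM in this assay.

Compound 3 shares the highest of these three numbers with compound 1, the pair being separated by no change at the digits printed from compound 1 to compound 3 (within the scatter), while compound 2 sits apart, as a 2.5-fold higher number from compound 2 to compound 3 (0.40 log units; beyond the scatter) shows. Compound 4 `Cc1ccc(-c2ccc(S(=O)(=O)Nc3cccc(CO)c3)cc2)cc1` differs from compound 3 by a single change: methyl in place of chloro on an aromatic carbon. The measured step that bears most directly on it is the swap at the same place, no change at the digits printed from compound 1 to compound 3 (within the scatter), where one group replaced another with no effect beyond the scatter. The other step, a 2.5-fold lower number from compound 1 to compound 2 (0.40 log units; beyond the scatter), concerns a fluoro added elsewhere on the same ring and speaks less to this change. Among the measured compounds shown here, because the one comparable swap no change at the digits printed from compound 1 to compound 3 (within the scatter) left the number unchanged, compound 4 is expected to give a number close to that of compound 3. The expected step is a 1.2-fold higher number from compound 3 to compound 4 (0.08 log units; within the scatter), inside the scatter. Compound 4 is therefore estimated at 3000 nM, within a range from 1200 nM to 8000 nM.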

Compound 4, half-maximal inhibitory concentration: 1200 nM
Compound 4: middle estimate off by 2.5-fold (0.40 log units), on the high side; measured number inside the range.
By their numbers in this assay, from the lowest: compounds 2 and 4 (each within the scatter of the next); then compounds 1 and 3 (each within the scatter of the next).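

Methyl in place of chloro (a 2.1-fold lower number from compound 3 to compound 4 (0.32 log units; beyond the scatter)) and methyl in place of bromo (a 2.1-fold lower number from compound 1 to compound 4 (0.32 log units; beyond the scatter)) show that in this assay this position does respond to the group it carries, even though exchanging the two halogens left the number unchanged. The 4-methylphenyl group of compound 4 also sits level with the 4-bromo-2-fluorophenyl group of compound 2 (a 1.2-fold higher number from compound 2 to compound 4 (0.08 log units; within the scatter)), so two different changes to the 4-bromophenyl compound arrive at much the same number. Nothing measured here explains why methyl parts from the halogens.

The compounds shown leave open how an amine, a methoxy group or a longer chain such as ethyl would fare at this position. They also leave open whether the fluoro of compound 2 and the methyl of compound 4 would add up if placed on one ring.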